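Compound 3: 5-methylthiophen-2-yl in place of 4-fluorophenyl

This account rests on a few compounds, and the source may have more. Where it says the series, first, only, none or still open, it means among the compounds named here.

Compound 1 `O=C(NO)c1ccc(NCc2nc(-c3ccc(Cl)cc3)nn2-c2ccccc2)cc1`: 5970 nM
Compound 2 `O=C(NO)c1ccc(NCc2nc(-c3ccc(F)cc3)nn2-c2ccccc2)cc1`: 8960 nM

For the measured compounds named here, in a functional assay on MGC-803 cells (Homo sapiens) for antiproliferative activity, read by MTT assay, with a stated time of 72 h (on this read-out higher numbers stand for weaker inhibition and lower numbers for stronger inhibition), compound 2, at 8960 nM, cannot be told apart from compound 1, the only other measured compound. Compound 3 `Cc1ccc(-c2nc(CNc3ccc(C(=O)NO)cc3)n(-c3ccccc3)n2)s1` differs from compound 2 at one place: 5-methylthiophen-2-yl in place of 4-fluorophenyl on an aromatic carbon. Going by the values given here, only one measured step bears on this: a 1.5-fold higher number from compound 1 to compound 2 (0.18 log units; within the scatter). Among the compounds with values here, that step exchanges fluoro and chloro, and no measured step replaces the whole 4-fluorophenyl, so the guidance is weak. The expected size is a 1.3-fold lower number from compound 2 to compound 3 (0.11 log units; within the scatter), with no firm direction and nothing expected beyond the scatter. For compound 3 the estimated value is 7000 nM, with an expected range of 2500 nM to 20000 nM.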

Compound 3, half-maximal inhibitory concentration: 8450 nM
The estimate for compound 3 lay 1.2-fold (0.08 log units) below the measured number, within the range that was stated.
By their numbers in this assay, from the lowest: compounds 1, 3 and 2 (each within the scatter of the next).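

In this assay, exchanging the whole 4-fluorophenyl for 5-methylthiophen-2-yl gave a 1.1-fold lower number from compound 2 to compound 3 (0.03 log units; within the scatter), and exchanging 4-chlorophenyl for the same group gave a 1.4-fold higher number from compound 1 to compound 3 (0.15 log units; within the scatter). The earlier pair had shown only a change of halogen, whereas these steps show that a different ring, five-membered and carrying sulfur, leaves the number within the scatter at this position. No measurement available here accounts for this.

On these data alone, whether an amine, a carboxylic acid or a cyclohexyl group on this aromatic carbon would move the number beyond the scatter remains open.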